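This account rests on a few compounds, and the source may have more. Where it says the series, first, only, none or still open, it means among the compounds named here.

Series notes. Three analogues of the shared core carry different aryl groups on an amine nitrogen in a ring of a six-membered non-aromatic ring with 2 nitrogen. Compound 1 `Nc1scc(CN2CCN(c3ccccc3C(F)(F)F)CC2)c1C(=O)c1ccc(Cl)cc1` gives -39% in a functional assay on CHO cells with adenosine receptor A1 (Homo sapiens) as the target, read by cAMP accumulation and immunoassay, with a stated time of 6 min, tested at 1 uM; on this read-out lower numbers stand for a stronger effect and higher numbers for a weaker effect at the one concentration tested. Compound 2 `Nc1scc(CN2CCN(c3ccc(Cl)c(C(F)(F)F)c3)CC2)c1C(=O)c1ccc(Cl)cc1` gives -47%, and compound 3 `Nc1scc(CN2CCN(c3ccc(F)cc3F)CC2)c1C(=O)c1ccc(Cl)cc1` gives -66%. Compound 3 holds the lowest, that is the strongest, number of the three: the step of a number 27 percentage points lower from compound 1 to compound 3 (beyond the scatter) and the step of a number 19 percentage points lower from compound 2 to compound 3 (beyond the scatter) both lie beyond the scatter, whereas a number 8 percentage points lower from compound 1 to compound 2 (within the scatter) does not.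

Compound 4 `Nc1scc(CN2CCN(c3cc(F)cc(F)c3)CC2)c1C(=O)c1ccc(Cl)cc1` has not been measured. It differs from compound 3 in one place: 3,5-difluorophenyl in place of 2,4-difluorophenyl on an amine nitrogen in a ring

For the measured compounds named here, none of the measured steps is this same move of the two fluorines around the ring; the steps that bear on it are the aryl swaps on this nitrogen, which ranged from within the scatter to modest. Going by the values given here, compound 3 is the only difluorophenyl case, so there is no direct precedent. A modest weakening, a higher number, relative to compound 3 is therefore expected, with wide uncertainty. The step of a number 16 percentage points higher from compound 3 to compound 4 (beyond the scatter) is the estimate. Compound 4 is expected to give -50%, within a range of -75% to -25%.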

Compound 4, a percentage reported as activity, at one concentration (the size of the read-out at that concentration, not a potency): -66%
Estimate against measurement, compound 4: 16 percentage points above; the measured number falls inside the stated range.
By their numbers in this assay, from the lowest: compounds 3 and 4 (each within the scatter of the next); then compounds 2 and 1 (each within the scatter of the next).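

In this assay, moving the two fluorines from the 2,4-difluorophenyl to the 3,5-difluorophenyl pattern on the amine nitrogen in a ring gives no change at the digits printed from compound 3 to compound 4 (within the scatter), so the result at compound 3 is no longer a single difluorophenyl case, and these two fluorine patterns cannot be told apart on this read-out. The separation from the trifluoromethyl-bearing aryl groups also carries over to the new pattern, with a number 19 percentage points lower from compound 2 to compound 4 (beyond the scatter) and a number 27 percentage points lower from compound 1 to compound 4 (beyond the scatter); across these four compounds, both difluorophenyl groups sit on the stronger side of both trifluoromethyl-bearing groups, and none of the four goes against this. Nothing available here accounts for the match between the two fluorine patterns.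

Going by these compounds, whether the same result holds for a phenyl ring with a single fluorine, an unsubstituted phenyl, or a phenyl carrying a methoxy group or a carboxylic acid remains open. On these data alone, with a read-out at one concentration, it also remains open whether compound 3 and compound 4 would still match in potency across a range of concentrations.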